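Swapping one alkyl group on the shared core

This account rests on a few compounds, and the source may have more. Where it says the series, first, only, none or still open, it means among the compounds named here.

Compound 1 `CC(/N=c1\c(O)c(O)\c1=N/c1ccc(C#N)cc1)C(C)(C)C`: 520 nM
Compound 2 `C[C@@H](/N=c1\c(O)c(O)\c1=N/c1ccc(C#N)cc1)C(C)(C)C`: 370 nM; 24300 nM (2 entries)

Among the measured compounds shown here, in a functional assay for inhibition, with Rattus norvegicus as the target (on this read-out lower numbers stand for stronger inhibition and higher numbers for weaker inhibition), compound 1 gives 520 nM, its only number, alongside one further entry without a number. Compound 2, drawn with a defined configuration, has two entries that lie far apart. Compound 3 `CC(C)(C)/N=c1\c(O)c(O)\c1=N/c1ccc(C#N)cc1` keeps the shared core but carries tert-butyl in place of 1,2,2-trimethylpropyl on a double-bonded nitrogen. For the measured compounds named here, no measured pair shows what this swap does, so no change beyond the scatter is expected. The expected step is a 1.3-fold higher number from compound 1 to compound 3 (0.13 log units; within the scatter). For compound 3 the estimate is 700 nM, with an expected range of 120 nM to 4000 nM.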

Compound 3, half-maximal inhibitory concentration: 560 nM
Estimate against measurement, compound 3: 1.3-fold (0.10 log units) above, and the stated range covers the measured number.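

In this assay, putting tert-butyl in place of 1,2,2-trimethylpropyl on a double-bonded nitrogen gives a 1.1-fold higher number from compound 1 to compound 3 (0.03 log units; within the scatter). Among the compounds shown here, this is the first measured swap at this place, and it shows that these two alkyl groups cannot be told apart on this read-out. The extra carbons of 1,2,2-trimethylpropyl are therefore not needed to keep inhibition at this level.

On these data alone, what an amine, a carboxylic acid or a longer chain would do at this place remains open. Whether the drawn configuration matters also remains unsettled: the several entries of compound 2 in this assay, 370 nM; 24300 nM (2 entries)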